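The source may hold more compounds than are shown below. What is called first, only, known or untested is meant among the compounds shown, and "the series" means these compounds.

Measured in a functional assay on A2780 cells (Homo sapiens) for inhibition; on this read-out higher numbers stand for weaker inhibition and lower numbers for stronger inhibition:
- compound 1 `C[C@H](C(=O)Nc1cc(C2CC2)[nH]n1)c1ccc(N2CCCC2)cc1`: 220 nM
- compound 2 `C[C@H](C(=O)Nc1cc(C2CC2)[nH]n1)c1ccc(N2CCNC2=O)cc1`: 1270 nM
- compound 3 `C[C@H](C(=O)Nc1cc(C2CC2)[nH]n1)c1ccc(N2Cc3ccccc3C2=O)cc1`: 1020 nM

Compound 1 has the lowest number of the three and so is the strongest inhibitor in this assay, clear of compound 3 at 1020 nM and of compound 2 at 1270 nM. Compound 4 `CC(C(=O)Nc1cc(C2CC2)[nH]n1)c1ccc(N2CCCC2)cc1` is the next to consider, and it has the same atoms and bonds as compound 1: the two compounds have the same atoms and bonds; at least one stereo element is drawn with a configuration in one of them and without one in the other: 1 of 1 stereo elements differ; a stereocentre at a saturated chain carbon is drawn S in compound 1 and without a configuration in compound 4. For the measured compounds named here, the only measured step between compounds differing in one place, a 5.8-fold higher number from compound 1 to compound 2 (0.76 log units; beyond the scatter), swaps pyrrolidin-1-yl for 2-oxoimidazolidin-1-yl, leaves the stereocentre untouched and is no guide to this change. Going by the values given here, no measured pair tests the configuration, so the expectation is weakly founded. At most a small move toward a higher number is expected, near the edge of the scatter, and the estimate is a 1.5-fold higher number from compound 1 to compound 4 (0.19 log units; within the scatter). For compound 4 the expected value is 340 nM, with an estimated range from 180 nM to 650 nM.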

Compound 4, half-maximal inhibitory concentration: 370 nM
Compound 4: the middle estimate sits 1.1-fold (0.04 log units) below what was measured; low and high end bracket the measured number.
By their numbers in this assay, from the lowest: compounds 1 and 4 (each within the scatter of the next); then compounds 3 and 2 (each within the scatter of the next).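

In this assay, the stereocentre at the saturated chain carbon now has a measured step of its own, a 1.7-fold higher number from compound 1 to compound 4 (0.23 log units; within the scatter), so compound 1 and compound 4 cannot be told apart on this read-out. This sets the stereocentre apart from the aromatic substituent, where the earlier step, a 5.8-fold higher number from compound 1 to compound 2 (0.76 log units; beyond the scatter), lies beyond the scatter. The only difference behind the new step is a matter of how the stereocentre is drawn: the fact that one of compounds 1 and 4 is drawn with a defined configuration and the other without, at the place where they differ

Compound 4 carries no drawn configuration. The compounds shown do not settle how a compound drawn R at this stereocentre would read. They also leave open whether piperidin-1-yl or morpholin-4-yl in place of pyrrolidin-1-yl would stay near the number of compound 1 or move toward that of compound 2.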